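Alkyl variation on the ring nitrogen of the shared core

A few compounds are considered here, and "the series" means these few. Any claim that something is new, unique, unknown or untested is made for them only; others in the source may bear on it.

Three compounds of this series carry the same chlorinated fused core and differ only at the ring nitrogen or at the amino group. Compound 1 `Cc1ccc(C(=O)Nc2nc(Cl)c3cn(CC(C)(C)C)nc3n2)cc1` bears an amide on the amino group and, in an assay on CHO cells for displacement of a labelled ligand from adenosine receptor A1 (Homo sapiens), read by scintillation counting, with a stated time of 3 h (on this read-out higher numbers stand for weaker inhibition and lower numbers for stronger inhibition), compound 1 gives 11100 nM. Compound 2 `CC(C)(C)Cn1cc2c(Cl)nc(N)nc2n1` keeps the free amino group and gives 12000 nM. Within the data shown here, compound 3 `Cn1cc2c(Cl)nc(N)nc2n1`, with methyl on the aromatic nitrogen, gives 29700 nM, the highest of the three numbers; the step of a 2.5-fold higher number from compound 2 to compound 3 (0.39 log units; beyond the scatter) is the one measured change at this position and is modest in size.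

Compound 4 `CC(C)n1cc2c(Cl)nc(N)nc2n1` is the next member: isopropyl in place of methyl on an aromatic nitrogen. Among the measured compounds shown here, the only step bearing on it is the one from compound 2 to compound 3, where removing tert-butyl from the chain raised the number; isopropyl restores part of that chain bulk, so a partial return is expected. For compound 4 the estimate in this assay is 18000 nM, with a range from 8000 nM to 40000 nM, meaning an expected step of a 1.7-fold lower number from compound 3 to compound 4 (0.22 log units; within the scatter).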

Compound 4, inhibition constant: 9000 nM
Estimate against measurement, compound 4: 2.0-fold (0.30 log units) above; the measured number falls inside the stated range.
By their numbers in this assay, from the lowest: compounds 4, 1 and 2 (each within the scatter of the next); then compound 3.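

In this assay, the step of a 3.3-fold lower number from compound 3 to compound 4 (0.52 log units; beyond the scatter) shows that the methyl compound's number is not recovered only with the neopentyl chain: isopropyl on the aromatic nitrogen is enough. The further comparison, a 1.3-fold lower number from compound 2 to compound 4 (0.12 log units; within the scatter), leaves isopropyl and neopentyl indistinguishable here, so among these three groups only methyl stands apart. Nothing on hand gives a reason for either step.

Still open, on these data alone, is whether an ethyl group, a cyclopropyl ring or a longer unbranched chain on this nitrogen would stay with isopropyl and neopentyl or move towards methyl, and whether a chain ending in an amine or a carboxylic acid would be tolerated. Also open, as far as these compounds go, is how the amide on the amino group of compound 1 would read with isopropyl on the ring nitrogen.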